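Swapping Methyl for Methoxy on a Pyridine Ring

This account rests on a few compounds, and the source may have more. Where it says the series, first, only, none or still open, it means among the compounds named here.

Compound 1 `Fc1ccc(OC[C@H]2CCN2)cn1`: 0.066 nM
Compound 2 `Cc1ccc(OC[C@H]2CCN2)cn1`: 0.053 nM

In an assay on brain for binding affinity to Neuronal acetylcholine receptor; alpha4/beta2 (Rattus norvegicus), read by radioligand binding (a higher number here means a weaker inhibitor, a lower number a stronger inhibitor), compound 2 gives 0.053 nM, the lowest of the two numbers, though its gap to compound 1 is within the scatter, as the step of a 1.2-fold lower number from compound 1 to compound 2 (0.10 log units; within the scatter) shows. Compound 3 `COc1ccc(OC[C@H]2CCN2)cn1` differs from compound 2 by methoxy in place of methyl on an aromatic carbon, placed on an aromatic carbon of a six-membered aromatic ring with one nitrogen, next to the ring nitrogen. Among the measured compounds shown here, the only step that bears on this change is a 1.2-fold lower number from compound 1 to compound 2 (0.10 log units; within the scatter), a small one. So a step of similar size is expected for a 2.3-fold higher number from compound 2 to compound 3 (0.35 log units; beyond the scatter). Compound 3 is therefore estimated at 0.12 nM, with a range from 0.04 nM to 0.4 nM.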

Compound 3, inhibition constant: 0.67 nM
Estimate against measurement, compound 3: 5.6-fold (0.75 log units) below; measured number above the stated range.
By their numbers in this assay, from the lowest: compounds 2 and 1 (each within the scatter of the next); then compound 3.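

In this assay the place next to the ring nitrogen turns out not to accept every small group alike: methoxy weakens binding in both available comparisons (a 13-fold higher number from compound 2 to compound 3 (1.10 log units; beyond the scatter); a 10-fold higher number from compound 1 to compound 3 (1.01 log units; beyond the scatter)), while fluoro and methyl stand within the scatter of each other. The near-silent first swap therefore did not describe this position as a whole. Nothing measured here explains the gap. Going by these compounds, what stays open is whether other groups at this place behave like methoxy or like methyl and fluoro; ethyl, hydroxyl or an amine would test that.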